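From a pyridine arm to a benzyl arm

The source may hold more compounds than are shown below. What is called first, only, known or untested is meant among the compounds shown, and "the series" means these compounds.

Compound 1, `CCN(Cc1ccccc1)Cc1ccc(CN2CCc3ccc(OS(N)(=O)=O)cc3C2)cc1`: 17%
Compound 2, `CCN(Cc1ccncc1)c1ccc(C(=O)N2CCc3ccc(OS(N)(=O)=O)cc3C2)cc1`: 86.6%
Compound 3, `CCN(Cc1ccncc1)c1cccc(C(=O)N2CCc3ccc(OS(N)(=O)=O)cc3C2)c1`: 52.8%

In an assay on HEK293 cells for inhibition of Steryl-sulfatase (Homo sapiens), tested at 1 uM (a lower number here means a weaker effect, a higher number a stronger effect of the compound at the concentration tested), compound 3 gives 52.8%, the second highest of the three numbers; compound 2 gives 86.6%, beyond the scatter above it, and compound 1 gives 17%, beyond the scatter below it. Compound 4, `CCCN(Cc1ccccc1)c1cccc(C(=O)N2CCc3ccc(OS(N)(=O)=O)cc3C2)c1`, has not yet been measured. It differs from compound 3 in one place: benzyl(propyl)amino in place of ethyl((pyridin-4-yl)methyl)amino on an aromatic carbon. Within the data shown here, no pair of measured compounds differs in a single place, so this step has no direct precedent. Compound 1 also carries a benzyl group and gives the lowest number, yet it differs in further ways. The expected step in this assay is a modest decrease, near the edge of the scatter, a number 7.8 percentage points lower from compound 3 to compound 4 (within the scatter). Compound 4 is therefore estimated at 45%, between 22% and 68%.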

Compound 4, a percentage reported as inhibition, at one concentration (the size of the read-out at that concentration, not a potency): 67.4%
Compound 4: the middle estimate sits 22.4 percentage points below what was measured, within the range that was stated.
By their numbers in this assay, from the lowest: compound 1; then compound 3; then compound 4; then compound 2.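

At this place, on an aromatic carbon meta to a large group, the pyridine ring can be replaced by a ring of carbon only without losing the effect: in this assay, benzyl(propyl)amino in place of ethyl((pyridin-4-yl)methyl)amino gives a number 14.6 percentage points higher from compound 3 to compound 4 (beyond the scatter). The ring and the chain change together in this step, so the rise cannot be split between them. No measurement here explains the rise.

On these data alone, it remains open which of the two changes matters, and whether a butyl chain on that amine nitrogen would raise the number further.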